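The source may hold more compounds than are shown below. What is called first, only, known or untested is meant among the compounds shown, and "the series" means these compounds.

Within the data shown here, compound 2 `CN(C)/[N+]([O-])=N/Oc1cc(O/N=[N+](\[O-])N2CCCC2CO)c([N+](=O)[O-])cc1[N+](=O)[O-]` is one of two compounds measured so far in a functional assay on HL-60 cells (Homo sapiens) for antiproliferative activity, read by MTT assay, with a stated time of 72 h; on this read-out lower numbers stand for stronger inhibition and higher numbers for weaker inhibition. In this assay compound 2 gives 1000 nM. Among the measured compounds shown here, its only companion is compound 1 `CCOC(=O)N1CCN(/[N+]([O-])=N/Oc2cc(O/N=[N+](\[O-])N(C)C)c([N+](=O)[O-])cc2[N+](=O)[O-])CC1`, which in this assay gives 1200 nM; the step of a 1.2-fold lower number from compound 1 to compound 2 (0.08 log units; within the scatter) separates the two, and compound 2 therefore has the lower of the two numbers, while its gap to compound 1 lies inside the usual spread of repeated measurements, so no order between them can be claimed.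

Compound 3 `CCN(CC)/[N+]([O-])=N/Oc1cc(O/N=[N+](\[O-])N2CCCC2CO)c([N+](=O)[O-])cc1[N+](=O)[O-]` is not yet measured. It differs from compound 2 in one place: diethylamino in place of dimethylamino on a double-bonded nitrogen. For the measured compounds named here, the single measured step, from compound 1 to compound 2, concerns a change at the other double-bonded nitrogen of the shared core and says nothing about the dimethylamino group; no measured step bears on the present change. Without such a precedent, no step beyond the scatter is expected in this assay, in either direction. The estimate for compound 3 is thus 1000 nM, with a range from 400 nM to 2500 nM, meaning an expected step of no change at the digits printed from compound 2 to compound 3 (within the scatter).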

Compound 3, half-maximal inhibitory concentration: 1800 nM
Beside the measured number, compound 3's estimate is 1.8-fold (0.26 log units) below it; measured number inside the range.
By their numbers in this assay, from the lowest: compounds 2, 1 and 3 (each within the scatter of the next).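

Among these compounds, this is the first look at the dimethylamino position of the shared core: in this assay, diethylamino in place of dimethylamino on a double-bonded nitrogen gives a 1.8-fold higher number from compound 2 to compound 3 (0.26 log units; within the scatter), so compound 2 and compound 3 cannot be put in any order. The group at this position can therefore go from 3 heavy atoms to 5 heavy atoms, with no ring and no hydrogen-bond donors or acceptors in either group, without a change that stands clear of the usual spread of repeated measurements, at least with 2-(hydroxymethyl)pyrrolidin-1-yl on the other double-bonded nitrogen of the core. No independent measurement is available that could account for this result.

As far as these compounds go, whether a longer chain such as dipropylamino, or a ring amine such as pyrrolidin-1-yl or morpholin-4-yl, would move the number beyond the scatter at this position remains open. From the compounds shown here alone, it is equally open whether diethylamino would give a similar result when paired with 4-(ethoxycarbonyl)piperazin-1-yl, the group carried by compound 1.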